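Aryl substituent change in the hydroxamate series

This account rests on a few compounds, and the source may have more. Where it says the series, first, only, none or still open, it means among the compounds named here.

Measured so far:
compound 1 `C[C@H](CCCCC(=O)NO)Nc1c(Nc2ccc(N(C)C)cc2)c(=O)c1=O` gives < 5 uL/min in an ADME assay on cells (Hepatocyte, Homo sapiens) for pharmacokinetics, read by LC-MS, with a stated time of 90 min, tested at 1 uM (a lower number here means slower removal, a higher number faster removal of the compound), which is a limit of the assay and not a number.
compound 2 `C[C@@H](CCCCC(=O)NO)Nc1c(Nc2ccc(N(C)C)cc2)c(=O)c1=O` gives 3.6 uL/min in this assay.

Compound 1 stands at a limit only. The single measured step, a step that the limit leaves unreadable from compound 1 to compound 2, cannot be sized because of the limit of < 5 uL/min in this assay, at which 1 of the 2 values shown sits, and it concerns configuration alone, as shown by the fact that compounds 1 and 2 differ only in the configuration as drawn. Compound 3 `C[C@H](CCCCC(=O)NO)Nc1c(Nc2ccc(OC(F)(F)F)cc2)c(=O)c1=O` carries trifluoromethoxy in place of dimethylamino on an aromatic carbon, a change without precedent among these steps. Compound 3 is therefore expected to remain at low clearance, estimated at 4.5 uL/min (range 2 uL/min to 12 uL/min). The expected step that the limit leaves unreadable from compound 1 to compound 3 lies within the scatter.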

Compound 3, intrinsic clearance in a liver preparation (reported as CLH), per the amount of preparation that the assay uses in the Hepatocyte assay: 31 uL/min
Compound 3: the middle estimate sits 6.9-fold (0.84 log units) below what was measured; measured number outside the range, above it.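

In the Hepatocyte assay, trifluoromethoxy in place of dimethylamino on an aromatic carbon, para to a large group, gives an at least 6.2-fold higher number from compound 1 to compound 3 (0.79 log units; beyond the scatter) and shows that this position is not silent for removal. In a physicochemical assay for solubility, with a stated time of 24 h, tested at 30 mg/mL (a lower number here means a less soluble compound, a higher number a more soluble compound), the same change gives a 2.6-fold higher number from compound 1 to compound 3 (0.41 log units; beyond the scatter) with compound 1 at 27000000 nM and compound 3 at 70000000 nM in that read-out. Compound 1 stands at a limit in the Hepatocyte assay, and the step to compound 2 cannot be read.

On these data alone, whether the faster removal follows the loss of dimethylamino or the entry of trifluoromethoxy remains open. A methoxy group on the same aromatic carbon would help to separate the two.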